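This account rests on a few compounds, and the source may have more. Where it says the series, first, only, none or still open, it means among the compounds named here.

Measured compounds in an ADME assay on C8166 cells (Homo sapiens) for cytotoxicity, read by MTT assay; a higher number here means that more compound is tolerated, a lower number that less compound is tolerated:
- compound 1 `Cc1cc(S(N)(=O)=O)ccc1NC(=O)COc1ccc(Cl)cc1Oc1ccc2ccccc2c1Cl` gives 40700 nM
- compound 2 `Cc1cc(S(N)(=O)=O)ccc1NC(=O)COc1ccc(F)cc1Oc1ccc2ccccc2c1C` gives 56100 nM
- compound 3 `Cc1cc(S(N)(=O)=O)ccc1NC(=O)COc1ccc(F)cc1Oc1ccc2ccccc2c1Cl` gives 47100 nM

Compound 3 stands second highest of the three, with compound 1 nearest and compound 2 furthest, and both of those gaps are within the scatter. The two steps into compound 3 are small: a 1.2-fold higher number from compound 1 to compound 3 (0.06 log units; within the scatter) and a 1.2-fold lower number from compound 2 to compound 3 (0.08 log units; within the scatter). The three measured compounds therefore sit on one level in this assay, and neither halogen exchange nor the methyl-to-chloro exchange moved the number beyond the scatter.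

Compound 4 `Cc1cc(S(N)(=O)=O)ccc1NC(=O)COc1ccc(F)cc1Oc1ccc2cc(C#N)ccc2c1Cl` differs from compound 3 by cyano in place of hydrogen on an aromatic carbon. Going by the values given here, no measured step bears on a cyano substituent, nor on any change at that ring; the measured changes sit elsewhere on the core. Among the compounds with values here, the only guide is the flatness of the series so far, where both changes gave steps within the scatter. On that basis compound 4 is expected to stay near compound 3, with a step of a 1.0-fold lower number from compound 3 to compound 4 (0.02 log units; within the scatter) that is expected to remain within the scatter. The estimate for compound 4 is 45000 nM, with a range from 22000 nM to 90000 nM.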

Compound 4, half-maximal cytotoxic concentration: 39700 nM
Beside the measured number, compound 4's estimate is 1.1-fold (0.05 log units) above it; the measured number falls inside the stated range.
By their numbers in this assay, from the lowest: compounds 4, 1, 3 and 2 (each within the scatter of the next).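

Going by these compounds alone, compounds 1 to 3 differ only at other places on the shared core, so compound 4 gives the first reading at this aromatic carbon, meta to a fused ring and para to a fused ring. In this assay, cyano in place of hydrogen gives a 1.2-fold lower number from compound 3 to compound 4 (0.07 log units; within the scatter), so this position accepts a group of two heavy atoms with a triple bond without the number leaving the level of the series. Nothing available explains this flat result.

On these data alone, whether the level holds at this position for an amine, a carboxylic acid or a longer chain remains open. Also open, as far as these compounds go, is whether cyano gives the same small step on the core of compound 1 or compound 2, which carry other groups at the places already varied.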